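Furan-3-yl in place of phenyl on the shared core

The source may report more compounds than this note shows. Statements on the series, on what has been measured and on what is new or still open speak of the compounds shown alone.

Compound 2 `Cc1nc(N)c2c(-c3ccccc3)cn([C@@H]3O[C@H](CO)[C@@H](O)[C@H]3O)c2n1` belongs to a small set of ribosides together with compound 1 `CN(C)c1ncnc2c1c(-c1ccsc1)cn2[C@@H]1O[C@H](CO)[C@@H](O)[C@H]1O` and compound 3 `Nc1nc(N)c2c(-c3ccccc3)cn([C@@H]3O[C@H](CO)[C@@H](O)[C@H]3O)c2n1`. In an ADME assay on BJ cells (Homo sapiens), read by MTT assay, with a stated time of 72 h (a higher number here means a weaker inhibitor, a lower number a stronger inhibitor), compound 2 gives only a limit, > 100000 nM. Compound 1 likewise gives a limit of > 100000 nM. Compound 3 also returns a limit, > 100000 nM. Among the compounds with values here, the only single-site step, a step that the two limits leave unreadable from compound 2 to compound 3, is left unreadable by the two limits; (the limit of > 100000 nM in this assay, at which 3 of the 3 values shown sit). Compound 4 `Cc1nc(N)c2c(-c3ccoc3)cn([C@@H]3O[C@H](CO)[C@@H](O)[C@H]3O)c2n1` differs from compound 2 by furan-3-yl in place of phenyl on an aromatic carbon. Within the data shown here, no measured step bears on this change, and every value so far sits at the limit, so the step of a number no higher from compound 2 to compound 4 (the limit leaves the size open) is expected to amount to nothing readable. Compound 4 is therefore estimated at 100000 nM, within 30000 nM to 300000 nM.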

Compound 4, half-maximal inhibitory concentration: > 100000 nM
Compound 4: a limit, no number; the forecaster's own chance of this, stated with the estimate: 85%; the middle value lies on the limit itself.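

No step can be read between compound 2 and compound 4 in this assay, because both values are limits: the limit of > 100000 nM in this assay, at which 4 of the 4 values shown sit.

The compounds shown leave open the size of any single-site change on the shared core in this assay.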